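Amine sulfonylation on the long-chain amide core

This account rests on a few compounds, and the source may have more. Where it says the series, first, only, none or still open, it means among the compounds named here.

Compound 1 `CCCCCCCCCCCCCCCCCCNC(=O)[C@@H](N)[C@@H](C)O` carries a free amine on the shared core. In a functional assay on HepG2 cells (Homo sapiens) for cytotoxicity, read by MTT assay, with a stated time of 48 h (a lower number here means a stronger inhibitor, a higher number a weaker inhibitor), compound 1 gives 44500 nM, the lowest of the two numbers at hand. Compound 2 `CCCCCCCCNC(=O)[C@@H](NC(=O)c1nccc2ccccc12)[C@@H](C)O` differs from compound 1 in more than one place and is not a single-change neighbour; in this assay compound 2 gives 88200 nM, a value within the scatter of compound 1, so the two numbers show no ordering.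

Compound 3 `CCCCCCCCCCCCCCCCCCNC(=O)[C@@H](NS(=O)(=O)c1cccs1)[C@@H](C)O` follows from compound 1 by one change: (thiophen-2-yl)sulfonyl in place of hydrogen on an amine nitrogen. For the measured compounds named here, no measured pair in the set isolates this change; the only other substitution on that nitrogen, in compound 2, comes together with a different chain, so nothing can be separated from it. The step in this assay is therefore expected to be small, not beyond the scatter, in either direction. Compound 3 is estimated at 35000 nM, within 9000 nM to 130000 nM. The expected step is a 1.3-fold lower number from compound 1 to compound 3 (0.10 log units; within the scatter).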

Compound 3, half-maximal inhibitory concentration: > 200000 nM
Compound 3: a limit, no number; the forecaster's own chance of this, stated with the estimate: 15%; at least 5.7-fold (0.75 log units) between middle value and limit.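

On the amine nitrogen of the shared core, (thiophen-2-yl)sulfonyl in place of hydrogen gives, in this assay, an at least 4.4-fold higher number from compound 1 to compound 3 (0.65 log units; beyond the scatter). For the compounds shown here, this is the first single-change reading at this position, and it shows that the position is not indifferent to substitution: the step lies beyond the scatter and runs towards a higher number. For compound 3 the result is a limit of the assay and not a number: the limit of > 200000 nM in this assay, at which 1 of the 3 values shown sits.

Going by these compounds alone, the full size of the step remains unknown, and compound 2 differs in more than one place, so no step involving it can be read. Going by these compounds, whether the step follows the sulfonyl link or the thiophene ring stays open; a phenylsulfonyl or an acetyl group on the same nitrogen, with the chain of compound 1 kept, would separate the two.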